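Cyclic Tertiary Amide Replaces Cyclopentylamide: Expected Paw-Edema Inhibition

The source may hold more compounds than are shown below. What is called first, only, known or untested is meant among the compounds shown, and "the series" means these compounds.

Compound 1 `COc1cc2c(cc1OC)C(CC(N)=O)CC2`: 18.8%
Compound 2 `COc1cc2c(cc1OC)C(CC(=O)N(C)C)CC2`: 25%
Compound 3 `COc1cc2c(cc1OC)C(CC(=O)NC1CCCC1)CC2`: 40.6%

All three compounds share one core and differ only in the group on the carbonyl carbon of the side chain. Measured in a functional assay on the whole organism (strain Wistar) for inhibition, with Rattus norvegicus as the target, read by paw edema, with stated times of 60 min and 1 h, at a dose of 100 mg/kg by the oral route (a lower number here means less inhibition, a higher number more inhibition at the dose given (going by the name of the read-out)), compound 3 stands highest of the three, with the step of a number 15.6 percentage points higher from compound 2 to compound 3 (beyond the scatter) and the step of a number 21.8 percentage points higher from compound 1 to compound 3 (beyond the scatter) both beyond the scatter. The step of a number 6.2 percentage points higher from compound 1 to compound 2 (within the scatter) lies within the scatter, so compound 1 and compound 2 cannot be told apart on these numbers.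

Compound 4 `COc1cc2c(cc1OC)C(CC(=O)N1CCNCC1)CC2` is not yet measured. It differs from compound 3 in one place: piperazin-1-yl in place of cyclopentylamino on a carbonyl carbon. Among the compounds with values here, two measured steps bear on this change. The step of a number 15.6 percentage points higher from compound 2 to compound 3 (beyond the scatter) shows that exchanging one amine for another on this carbonyl carbon can shift the read-out by a modest amount, and the step of a number 6.2 percentage points higher from compound 1 to compound 2 (within the scatter) shows that a tertiary amide, which compound 4 also carries, gave no gain beyond the scatter over compound 1. Compound 4 is therefore expected to lose part of the advantage of compound 3, an estimated step of a number 13.6 percentage points lower from compound 3 to compound 4 (beyond the scatter) in this assay. The estimate for compound 4 in this assay is 27%, with a range from 12% to 42%.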

Compound 4, a percentage reported as inhibition, in the whole organism at one dose (the size of the read-out at that dose, not a potency): 62.5%
For compound 4 the middle estimate is 35.5 percentage points below the measured one; measured number above the stated range.
By their numbers in this assay, from the lowest: compounds 1 and 2 (each within the scatter of the next); then compound 3; then compound 4.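

In this assay, piperazin-1-yl on this carbonyl carbon gives a number 21.9 percentage points higher from compound 3 to compound 4 (beyond the scatter), and the gain grows to a number 37.5 percentage points higher from compound 2 to compound 4 (beyond the scatter) and a number 43.7 percentage points higher from compound 1 to compound 4 (beyond the scatter). The earlier compounds shown here gave no sign of this: the dimethylamino tertiary amide of compound 2 could not be told apart from the unsubstituted amide of compound 1, whereas compound 4, also a tertiary amide, has the highest number of the four, so being a tertiary amide does not by itself hold the read-out down at this position. The change swaps a five-membered carbon ring for a six-membered ring with a second nitrogen, but nothing available here shows why this raises the number.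

These compounds do not separate the effect of that second ring nitrogen from the effect of having a six-membered ring, a question that piperidin-1-yl, with carbon at that ring position, or morpholin-4-yl, with oxygen there, would address. Also open, as far as these compounds go, is what a group on the free ring nitrogen, such as the methyl of 4-methylpiperazin-1-yl, would do to the read-out.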